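The compounds below may be only part of what the source reports. "The series", "measured", "known", "first", "only" and "open" are said of these compounds alone.

Three compounds measured in an assay on isolated protein for inhibition of Gonadotropin-releasing hormone receptor (Homo sapiens) (a higher number here means a weaker inhibitor, a lower number a stronger inhibitor), share a core carrying a sulfur-linked benzyl group. Compound 1 `CC(C)n1c(SCc2ccccc2Cl)nc2cc(NC(=O)C3CC3)ccc21` gives 6300 nM. Compound 2 `COc1ccc([N+](=O)[O-])cc1CSc1nc2cc(NC(=O)NC(C)(C)C)ccc2n1-c1ccccc1` gives 350 nM. Compound 3 `COc1ccc([N+](=O)[O-])cc1CSc1nc2cc(NC(=O)OC(C)(C)C)ccc2n1C(C)C` gives 880 nM, the second highest of the three numbers: compound 2 sits at a lower number and compound 1 at a higher one, both differences beyond the usual scatter. Compound 4 `COc1ccc([N+](=O)[O-])cc1CSc1nc2cc(NC(=O)C3CCC3)ccc2n1C(C)C` has not been measured; it differs from compound 3 by cyclobutyl in place of tert-butoxy on a carbonyl carbon. Among the measured compounds shown here, no measured pair shows this exact change, so the step is estimated from the structures alone: a small rise in number or none beyond the scatter, a 1.4-fold higher number from compound 3 to compound 4 (0.13 log units; within the scatter). Compound 4 is therefore expected to give about 1200 nM, within a range from 400 nM to 3600 nM.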

Compound 4, half-maximal inhibitory concentration: 1500 nM
Estimate against measurement, compound 4: 1.3-fold (0.10 log units) below, and the stated range covers the measured number.
By their numbers in this assay, from the lowest: compound 2; then compounds 3 and 4 (each within the scatter of the next); then compound 1.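

In this assay the change gives a 1.7-fold higher number from compound 3 to compound 4 (0.23 log units; within the scatter) and so shows that, on this carbonyl carbon, the oxygen-containing tert-butoxy can give way to the all-carbon, four-membered cyclobutyl without moving the number beyond the scatter. Neither compound 1 nor compound 2 could show this, as each differs from compound 3 in more than one place. Nothing available explains why the two groups read alike.

Still open, as far as these compounds go, is how a longer chain, a phenyl ring or a dimethylamino group would read on this carbonyl carbon. Also open, from the compounds shown here alone, is whether the same change would read alike with phenyl in place of the isopropyl group.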